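Amide aryl swap in MT4 cytotoxicity series

The source may report more compounds than this note shows. Statements on the series, on what has been measured and on what is new or still open speak of the compounds shown alone.

Measured so far:
Compound 1 `Cc1cccc(NC(=O)CS(=O)(=O)c2nccc(Oc3c(C)cc(C#N)cc3C)n2)c1` gives 25700 nM in an ADME assay on MT4 cells (Homo sapiens) for cytotoxicity, read by MTT assay, with a stated time of 4 days; a lower number here means that less compound is tolerated, a higher number that more compound is tolerated.
Compound 2 `Cc1ccc(NC(=O)CS(=O)(=O)c2nccc(Oc3c(C)cc(C#N)cc3C)n2)cc1C` gives 13900 nM.
Compound 3 `Cc1cc(C#N)cc(C)c1Oc1ccnc(S(=O)(=O)CC(=O)Nc2ccc(Cl)cc2Cl)n1` gives 10400 nM.

Compound 2 sits between the other two numbers and is separated from neither beyond the scatter: a 1.8-fold lower number from compound 1 to compound 2 (0.27 log units; within the scatter) and a 1.3-fold lower number from compound 2 to compound 3 (0.13 log units; within the scatter). Among the compounds with values here, the one step that does register is a 2.5-fold lower number from compound 1 to compound 3 (0.39 log units; beyond the scatter), a modest one.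

Compound 4 `Cc1cc(C#N)cc(C)c1Oc1ccnc(S(=O)(=O)CC(=O)Nc2ccc(Cl)c(Cl)c2)n1` differs from compound 2 in one place: 3,4-dichlorophenyl in place of 3,4-dimethylphenyl on an amide-type nitrogen. The closest measured comparison is the exchange from compound 2 to compound 3, where a dichlorophenyl also replaced a dimethylphenyl and the number moved only within the scatter. The move from compound 1 to compound 3, toward a dichlorophenyl as well, was modest. Taken together, a small downward shift in this assay is expected for compound 4, one that may not clear the scatter; the expected step is a 1.3-fold lower number from compound 2 to compound 4 (0.12 log units; within the scatter). The estimate for compound 4 is 10500 nM, with a range from 5000 nM to 22000 nM.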

Compound 4, half-maximal cytotoxic concentration: 11700 nM
Compound 4: the middle estimate sits 1.1-fold (0.05 log units) below what was measured, and the stated range covers the measured number.
By their numbers in this assay, from the lowest: compounds 3, 4, 2 and 1 (each within the scatter of the next, the first and the last beyond it).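

At the group on the amide-type nitrogen, 3,4-dichlorophenyl in place of 3,4-dimethylphenyl leaves this assay within the scatter (a 1.2-fold lower number from compound 2 to compound 4 (0.07 log units; within the scatter)). The 3,4-dichlorophenyl and 2,4-dichlorophenyl groups also cannot be told apart (a 1.1-fold higher number from compound 3 to compound 4 (0.05 log units; within the scatter)), while compound 4 joins compound 3 as a second dichlorophenyl compound separated from the 3-methylphenyl of compound 1 beyond the scatter, though only modestly (a 2.2-fold lower number from compound 1 to compound 4 (0.34 log units; beyond the scatter)). No measurement at hand accounts for these numbers.

Still open, on these data alone, is whether an aryl group carrying an amine or a carboxylic acid, or a cyclohexyl group in place of the aryl, would shift the number further than the chlorine and methyl variants do. Also open, as far as these compounds go, is where an unsubstituted phenyl would fall relative to compound 1 and the dichlorophenyl compounds.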